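A few compounds are considered here, and "the series" means these few. Any claim that something is new, unique, unknown or untested is made for them only; others in the source may bear on it.

Three compounds share one core and differ only in the chain attached to a sulfur. Compound 1 `CC1=C(SCCCO)C(=O)c2ccccc2C1=O` carries the shortest hydroxy-bearing chain, compound 2 `CC1=C(SCCCCO)C(=O)c2ccccc2C1=O` a longer one and compound 3 `CC1=C(SCCCCCCO)C(=O)c2ccccc2C1=O` the longest. In a functional assay on WI-38 cells (Homo sapiens) for inhibition (a higher number here means a weaker inhibitor, a lower number a stronger inhibitor), compound 1 gives > 10000 nM, which is a limit of the assay and not a number. Compound 2 likewise gives > 10000 nM, again a limit. Compound 3 gives > 10000 nM, also a limit. All three values share (the limit of > 10000 nM in this assay, at which 3 of the 3 values shown sit), so compound 3 stands nowhere distinguishable from the other two, and the steps a step that the two limits leave unreadable from compound 1 to compound 2, a step that the two limits leave unreadable from compound 1 to compound 3 and a step that the two limits leave unreadable from compound 2 to compound 3 cannot be sized in either direction.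

Compound 4 `CC1=C(SC(C)C(C)O)C(=O)c2ccccc2C1=O` is the next variation: 2-hydroxy-1-methylpropyl in place of 6-hydroxyhexyl on a sulfur. The chain on the sulfur becomes shorter and branched, and the hydroxy group sits closer to the sulfur than in any of the three measured compounds. Within the data shown here, no measured step has a readable size, so none of them gives a direction or a magnitude for this change; the only guide is that compound 3 sits at a limit. Compound 4 is therefore expected to give about 15000 nM in this assay, within a range from 4000 nM to 60000 nM, which means an expected step that the limit leaves unreadable from compound 3 to compound 4, most likely again reported only as a limit.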

Compound 4, half-maximal inhibitory concentration: > 10000 nM
Compound 4: only a limit was reported; the forecaster's own chance of this, stated with the estimate: 80%; the middle value does not contradict the limit.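

In this assay compound 4 gives > 10000 nM, again a limit of the assay and not a number. Its steps from compound 1, compound 2 and compound 3 therefore cannot be read, and the four compounds share one result: the limit of > 10000 nM in this assay, at which 4 of the 4 values shown sit.

On these data alone, whether any chain on the sulfur gives a readable value in this assay, and how chain length or branching would shift it, stays open.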